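This account rests on a few compounds, and the source may have more. Where it says the series, first, only, none or still open, it means among the compounds named here.

Compound 1 `N[C@@H](COP(=O)(O)OCCCOC(=O)CCc1ccccc1OCc1cccc(Oc2ccccc2)c1)C(=O)O` gives 0.48 in an assay on cells for activation of probable G-protein coupled receptor 34 (Mus musculus), with a stated time of 1 h; on this read-out higher numbers stand for larger maximal responses and lower numbers for smaller maximal responses.
Compound 2 `N[C@@H](COP(=O)(O)OCCCOC(=O)CCc1ccccc1OCc1cccc(Oc2ccccc2Cl)c1)C(=O)O` gives 0.069 in this assay.
Compound 3 `N[C@@H](COP(=O)(O)OCCCOC(=O)CCc1ccccc1OCc1cccc(Oc2ccc(Cl)cc2)c1)C(=O)O` gives 0.76 in this assay.

Compound 3 stands highest of the three: the gap a number 0.28 higher from compound 1 to compound 3 (beyond the scatter) and the gap a number 0.69 higher from compound 2 to compound 3 (beyond the scatter) both lie beyond the scatter. Compound 4 `N[C@@H](COP(=O)(O)OCCCOC(=O)CCc1ccccc1OCc1cccc(Oc2ccc(Cl)c(Cl)c2)c1)C(=O)O` differs from compound 3 by chloro in place of hydrogen on an aromatic carbon.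

Among the measured compounds shown here, two measured steps bear on this change, each adding a single chloro to the same phenoxy ring of compound 1. One of them, a number 0.28 higher from compound 1 to compound 3 (beyond the scatter), raised the response; the other, a number 0.41 lower from compound 1 to compound 2 (beyond the scatter), lowered it sharply. Whether a second chloro, placed ortho to the chloro group already present, behaves like the first or like the second is not settled by these data, so a step in either direction is possible. Weighing the two, a step no larger than the scatter is expected for compound 4, namely a number 0.040 lower from compound 3 to compound 4 (within the scatter). Compound 4 is therefore estimated at 0.72, with a range from 0.4 to 0.95.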

Compound 4, intrinsic activity: the largest response reached, as a fraction of the reference agonist's: 0.71
Compound 4: middle estimate off by 0.010, on the high side, and the stated range covers the measured number.
By their numbers in this assay, from the lowest: compound 2; then compound 1; then compounds 4 and 3 (each within the scatter of the next).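

In this assay, chloro in place of hydrogen ortho to a chloro group makes no difference beyond the scatter, a number 0.050 lower from compound 3 to compound 4 (within the scatter). The 3,4-dichlorophenyl group therefore keeps a gain over phenyl, a number 0.23 higher from compound 1 to compound 4 (beyond the scatter), and stands far from 2-chlorophenyl, a number 0.64 higher from compound 2 to compound 4 (beyond the scatter). This exchange of hydrogen for chloro thus has no single size across the series, and its outcome differs with the ring it enters: the same change on two cores in this assay, a number 0.41 lower (beyond the scatter) from compound 1 to compound 2 and a number 0.050 lower (within the scatter) from compound 3 to compound 4, 0.36 apart, beyond the scatter of two such steps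

The compounds shown leave open what a 3-chlorophenyl group would give without the chloro already present in compound 3, so the effect of this position on its own cannot be separated out. They also leave open whether this position would accept anything other than chloro, such as a methyl, a methoxy or an amine.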